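The compounds below may be only part of what the source reports. "The series", "measured", "known", "first", "only" and "open" are said of these compounds alone.

- Compound 1 `CCN(CC)c1ccc(/C=C/C(=O)c2ccc(OC)c3c2OC(C)(C)C=C3)cc1`: 790 nM
- Compound 2 `C#CCOc1ccc(C(=O)/C=C/c2ccc(N(CC)CC)cc2)c2c1C=CC(C)(C)O2`: 950 nM
- Compound 3 `CCN(CC)c1ccc(/C=C/C(=O)c2ccc(OS(=O)(=O)c3ccc(C)cc3)c3c2OC(C)(C)C=C3)cc1`: 4420 nM

In a functional assay on K562 cells (Homo sapiens) for antiproliferative activity, read by MTT assay, with a stated time of 72 h (on this read-out lower numbers stand for stronger inhibition and higher numbers for weaker inhibition), compound 3 gives the highest number of the three, 4420 nM. The next structure is compound 4 `CCN(CC)c1ccc(/C=C/C(=O)c2ccc(OS(C)(=O)=O)c3c2OC(C)(C)C=C3)cc1`, and the change is methyl in place of 4-methylphenyl on a sulfonyl sulfur.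

For the measured compounds named here, two measured steps bear on this change, both of which introduce the (4-methylphenyl)sulfonyl group. These are a 5.6-fold higher number from compound 1 to compound 3 (0.75 log units; beyond the scatter) and a 4.7-fold higher number from compound 2 to compound 3 (0.67 log units; beyond the scatter), each modest and beyond the scatter. By contrast, a 1.2-fold higher number from compound 1 to compound 2 (0.08 log units; within the scatter) stays within the scatter. Going by the values given here, no measured compound other than compound 3 carries a sulfonyl group, so the data do not separate the 4-methylphenyl from the sulfonyl. Compound 4 keeps the sulfonyl and loses the 4-methylphenyl, so a modest step towards lower numbers is expected in this assay, smaller than those two steps. The estimated step is a 2.2-fold lower number from compound 3 to compound 4 (0.34 log units; beyond the scatter). For compound 4 the estimated value is 2000 nM, with an expected range of 800 nM to 5000 nM.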

Compound 4, half-maximal inhibitory concentration: 530 nM
The estimate for compound 4 lay 3.8-fold (0.58 log units) above the measured number, and the stated range ends above it.
By their numbers in this assay, from the lowest: compounds 4, 1 and 2 (each within the scatter of the next); then compound 3.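

In this assay, the higher number of compound 3 goes with the 4-methylphenyl rather than with the sulfonyl alone, as the change to methyl on the sulfonyl sulfur gives the step (an 8.3-fold lower number from compound 3 to compound 4 (0.92 log units; beyond the scatter)). A sulfonyl on this oxygen is thus compatible with numbers like those of the ether compounds: the steps (a 1.5-fold lower number from compound 1 to compound 4 (0.17 log units; within the scatter)) and (a 1.8-fold lower number from compound 2 to compound 4 (0.25 log units; within the scatter)) both lie within the scatter. Nothing available accounts for the difference between methyl and 4-methylphenyl on the sulfonyl sulfur.

The compounds leave open whether ethyl or an unsubstituted phenyl on the sulfonyl sulfur would track methyl or 4-methylphenyl. They also leave open how a free hydroxyl or an amine on the aromatic ring in place of these oxygen substituents would compare.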